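Ring-substituent position on the arylimino group of the shared core

This account rests on a few compounds, and the source may have more. Where it says the series, first, only, none or still open, it means among the compounds named here.

Measured so far:
compound 1, `Cc1cccc(/N=C2/NC(=O)/C(=C/c3ccccn3)S2)c1`, 39.7%
compound 2, `O=C1N/C(=N/c2cccc([N+](=O)[O-])c2)S/C1=C\c1ccccn1`, 43.5%

Both were read in a functional assay on the whole organism (strain Wistar) for inhibition, with Rattus norvegicus as the target, read by paw edema, with stated times of 30 min and 120 min, at a dose of 10 mg/kg by the oral route; a higher number here means more inhibition at the dose given (going by the name of the read-out), a lower number less inhibition. Among the measured compounds shown here, compound 1 and compound 2 stand within the scatter of each other, so neither is set apart by the numbers in hand; the only measured step, a number 3.8 percentage points higher from compound 1 to compound 2 (within the scatter), swaps one group for another at a fixed position on the ring and says nothing about moving a group around the ring.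

The next compound, compound 3, `Cc1ccccc1/N=C1/NC(=O)/C(=C/c2ccccn2)S1`, keeps every atom of compound 1 and changes only where the methyl sits: 2-methylphenyl in place of 3-methylphenyl on a double-bonded nitrogen.

For the measured compounds named here, no measured step bears directly on this change. Going by the values given here, the one step in hand shows that a very different group at the same position on this ring left the number level, within the scatter, which gives no reason to expect a large movement from a position change either. The step from compound 1 to compound 3 is therefore expected to be a number 1.7 percentage points lower from compound 1 to compound 3 (within the scatter), that is, no change beyond the scatter in either direction.

Compound 3 is estimated at 38% in this assay, with a likely range from 27% to 50%.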

Compound 3, a percentage reported as inhibition, in the whole organism at one dose (the size of the read-out at that dose, not a potency): 30.4%
For compound 3 the middle estimate is 7.6 percentage points above the measured one; the measured number falls inside the stated range.
By their numbers in this assay, from the lowest: compounds 3, 1 and 2 (each within the scatter of the next, the first and the last beyond it).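

In this assay, among the compounds shown here, the first reading on where a group sits rather than which group it is comes from the change to 2-methylphenyl in place of 3-methylphenyl on a double-bonded nitrogen, with the same atoms joined differently: a number 9.3 percentage points lower from compound 1 to compound 3 (within the scatter). Since this step lies within the scatter, the numbers in hand do not set the two methyl placements apart, and the result does not show that placement on this ring matters at this dose. Nothing measured alongside these numbers offers an explanation for this step.

Still open, on these data alone, is whether a carboxylic acid, an amine or a longer chain such as propyl in place of the methyl would give a step beyond the scatter, and whether the nitro group of compound 2 would read the same at another place on the ring. Each number in this assay also stands for a single oral dose, so it gives the size of the read-out at that dose and leaves open how these compounds would compare across a range of doses.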